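Four analogues of one core in a calcium flux readout

The source may report more compounds than this note shows. Statements on the series, on what has been measured and on what is new or still open speak of the compounds shown alone.

Values in a functional assay on HL-60 cells (Homo sapiens), read by calcium flux; a higher number here means that more compound is needed for the effect, a lower number that less compound is needed:
compound 1 `Cc1cc(Cc2cccc(Br)c2)c(=O)n(CC(=O)Nc2ccc(Br)cc2)n1`: > 50000 nM, a limit
compound 2 `Cc1cc(Cc2cccc3ccccc23)c(=O)n(CC(=O)Nc2ccc(Br)cc2)n1`: > 50000 nM, a limit
compound 3 `Cc1cc(Cc2ccc(C(N)=O)cc2)c(=O)n(CC(=O)Nc2ccc(Br)cc2)n1`: > 50000 nM, a limit

Compound 1 sits at the assay limit, where all three measured values rest (the limit of > 50000 nM in this assay, at which 3 of the 3 values shown sit). The steps a step that the two limits leave unreadable from compound 1 to compound 2 and a step that the two limits leave unreadable from compound 1 to compound 3 exchange one aromatic group for another on the same saturated chain carbon, and both are unreadable because the limit of > 50000 nM in this assay, at which 3 of the 3 values shown sit, caps them. Compound 4 `Cc1cc(N)c(=O)n(CC(=O)Nc2ccc(Br)cc2)n1` removes that whole group: amino in place of 3-bromobenzyl on an aromatic carbon. Among the compounds with values here, no measured step reaches this change, so the record gives no direction. The working expectation is no readable gain: a step of a number no higher from compound 1 to compound 4 (the limit leaves the size open), an estimated value of 50000 nM, between 10000 nM and 200000 nM.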

Compound 4, half-maximal effective concentration: > 50000 nM
Compound 4: a limit, no number; the forecaster's own chance of this, stated with the estimate: 85%; the middle value lies on the limit itself.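

Within the data shown here, compound 4 gives > 50000 nM, a limit, so no step from compound 1 to compound 4 can be read: the limit of > 50000 nM in this assay, at which 4 of the 4 values shown sit. The compounds shown leave open which structural change, if any, would give a measurable value in this assay.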